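The source may hold more compounds than are shown below. What is called first, only, known or untested is meant among the compounds shown, and "the series" means these compounds.

Measured so far: compound 1 `CC(C)Oc1ccc(C2CC(c3ccc(O)cc3)=NN2C(=O)c2cccnc2)cc1` with 45400 nM; compound 2 `COc1ccc(C2CC(c3ccc(O)cc3)=NN2C(=O)c2cccnc2)cc1OC` with 53600 nM; compound 3 `COc1ccc(OC)c(C2CC(c3ccc(O)cc3)=NN2C(=O)c2cccnc2)c1` with 56800 nM.

In an ADME assay on HepG2 cells (Homo sapiens) for cytotoxicity, read by MTT assay, with a stated time of 7 days (a lower number here means a stronger inhibitor, a higher number a weaker inhibitor), compound 1 gives the lowest of the three numbers, but its gaps to the others are small: a 1.2-fold higher number from compound 1 to compound 2 (0.07 log units; within the scatter) and a 1.3-fold higher number from compound 1 to compound 3 (0.10 log units; within the scatter). Compound 4 `CCc1ccccc1C1CC(c2ccc(O)cc2)=NN1C(=O)c1cccnc1` differs from compound 1 in one place: 2-ethylphenyl in place of 4-isopropoxyphenyl on a saturated ring carbon. Among the measured compounds shown here, the steps that bear on this change are the other swaps of the aryl group on the same saturated ring carbon, a 1.2-fold higher number from compound 1 to compound 2 (0.07 log units; within the scatter), a 1.3-fold higher number from compound 1 to compound 3 (0.10 log units; within the scatter) and a 1.1-fold higher number from compound 2 to compound 3 (0.03 log units; within the scatter), all within the scatter. No step beyond the scatter is therefore expected, in either direction, for compound 4: a 1.1-fold higher number from compound 1 to compound 4 (0.02 log units; within the scatter). Compound 4 is estimated at 48000 nM, with a range from 24000 nM to 96000 nM.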

Compound 4, half-maximal inhibitory concentration: 35400 nM
Compound 4: middle estimate off by 1.4-fold (0.13 log units), on the high side, within the range that was stated.
By their numbers in this assay, from the lowest: compounds 4, 1, 2 and 3 (each within the scatter of the next).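

In this assay, replacing the oxygen-bearing aryl groups on the saturated ring carbon with 2-ethylphenyl, which has no hydrogen-bond acceptor, leaves every step within the scatter (a 1.3-fold lower number from compound 1 to compound 4 (0.11 log units; within the scatter)) (a 1.5-fold lower number from compound 2 to compound 4 (0.18 log units; within the scatter)) (a 1.6-fold lower number from compound 3 to compound 4 (0.21 log units; within the scatter)). At this position, then, the ether oxygens of compounds 1, 2 and 3 are not needed to keep the number in the same range. No measurement available here explains this flat response.

Going by these compounds, whether an amine or a carboxylic acid on this aryl ring would move the number beyond the scatter remains open. So does the effect of a chain longer than ethyl.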